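Urea series, azine variation: notes toward compound 4

This account rests on a few compounds, and the source may have more. Where it says the series, first, only, none or still open, it means among the compounds named here.

Measured so far in a functional assay (aorta) for inhibition, with Rattus norvegicus as the target; a higher number here means a weaker inhibitor, a lower number a stronger inhibitor:
compound 1, `CC(C)(C)c1ccc(C#N)cc1NC(=O)Nc1cccnc1`: 25700000 nM
compound 2, `CC(C)(C)c1ccc(C#N)cc1NC(=O)Nc1ccccn1`: 25700000 nM
compound 3, `CC(C)(C)c1ccc(C#N)cc1NC(=O)Nc1ccncc1`: 7800000 nM

Compound 3 has the lowest number of the three. The steps of a 3.3-fold lower number from compound 1 to compound 3 (0.52 log units; beyond the scatter) and a 3.3-fold lower number from compound 2 to compound 3 (0.52 log units; beyond the scatter) are alike in size and both beyond the scatter, whereas no change at the digits printed from compound 1 to compound 2 (within the scatter) shows nothing. So moving the ring nitrogen to the pyridin-4-yl position gives a modest gain; the pyridin-2-yl and pyridin-3-yl arrangements are indistinguishable here.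

Compound 4, `CC(C)(C)c1ccc(C#N)cc1NC(=O)Nc1cnccn1`, is not yet measured. It differs from compound 3 by pyrazin-2-yl in place of pyridin-4-yl on an amide-type nitrogen. The pyrazin-2-yl ring keeps none of the pyridin-4-yl arrangement that set compound 3 apart; its two nitrogens instead echo the pyridin-2-yl and pyridin-3-yl patterns of compound 2 and compound 1, both of which sit at the higher number. Among the compounds with values here, no measured step covers the addition of a second ring nitrogen, so the expectation rests only on this analogy: a modest rise in this assay, roughly undoing the gain seen in compound 3, is expected, a 2.3-fold higher number from compound 3 to compound 4 (0.36 log units; beyond the scatter). Compound 4 is therefore estimated at 18000000 nM in this assay, within 6000000 nM to 50000000 nM.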

Compound 4, half-maximal inhibitory concentration: 15300000 nM
For compound 4 the middle estimate is 1.2-fold (0.07 log units) above the measured one, and the stated range covers the measured number.
By their numbers in this assay, from the lowest: compounds 3, 4, 1 and 2 (each within the scatter of the next, the first and the last beyond it).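

In this assay pyrazin-2-yl on the amide-type nitrogen cannot be told apart from any of the three pyridinyl rings (a 2.0-fold higher number from compound 3 to compound 4 (0.29 log units; within the scatter)) (a 1.7-fold lower number from compound 2 to compound 4 (0.23 log units; within the scatter)) (a 1.7-fold lower number from compound 1 to compound 4 (0.23 log units; within the scatter)). Compound 4 thus stands within the scatter of both compound 3 and the pair compound 1 and compound 2, although compound 3 is separated from that pair beyond the scatter, so this ring with 2 hetero atoms joins neither side. No measurement available here bears on why these rings compare as they do.

Still open, as far as these compounds go, is whether phenyl or pyrimidin-5-yl at this place would fall clearly on one side of that gap. Also open, from the compounds shown here alone, is whether the pyridin-4-yl gain would persist with a carboxylic acid in place of the nitrile on the shared core.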